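The source may hold more compounds than are shown below. What is called first, only, known or untested is meant among the compounds shown, and "the series" means these compounds.

Measured in a functional assay on DU-145 cells (Homo sapiens) for inhibition, read by trypan blue exclusion, with a stated time of 96 h; on this read-out higher numbers stand for weaker inhibition of growth and lower numbers for stronger inhibition of growth:
compound 1 `Cc1ccc(CS(=O)(=O)/C(=C/c2c[nH]c3ccccc23)C(=O)c2ccc(Cl)cc2)cc1` gives 25000 nM
compound 2 `Cc1ccc(CS(=O)(=O)/C(=C/c2c(O)cc(O)cc2O)C(=O)c2ccc(Cl)cc2)cc1` gives > 100000 nM, which is a limit of the assay and not a number
compound 3 `Cc1ccc(CS(=O)(=O)/C(=C/c2sccc2C)C(=O)c2ccc(Cl)cc2)cc1` gives 25000 nM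

Compound 3 stands level with compound 1 at the digits shown: no change at the digits printed from compound 1 to compound 3 (within the scatter). Compound 2 sits at the limit, (the limit of > 100000 nM in this assay, at which 1 of the 3 values shown sits). Against it the steps are an at least 4.0-fold higher number from compound 1 to compound 2 (0.60 log units; beyond the scatter) and an at least 4.0-fold lower number from compound 2 to compound 3 (0.60 log units; beyond the scatter).

Compound 4 `Cc1ccc(CS(=O)(=O)/C(=C/c2ccc(Br)cc2)C(=O)c2ccc(Cl)cc2)cc1` differs from compound 3 by 4-bromophenyl in place of 3-methylthiophen-2-yl on a double-bonded chain carbon bound to a double-bonded chain carbon. The step that bears on this most is no change at the digits printed from compound 1 to compound 3 (within the scatter), where 1H-indol-3-yl gave way to 3-methylthiophen-2-yl on the same chain carbon without change. The steps to and from compound 2 concern only 2,4,6-trihydroxyphenyl. No step beyond the scatter is therefore expected for compound 4 in this assay. The estimate for compound 4 is 25000 nM, with range 8000 nM to 80000 nM. The expected step is no change at the digits printed from compound 3 to compound 4 (within the scatter).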

Compound 4, concentration for 50% growth inhibition: 25000 nM
The estimate for compound 4 equals the measured number at the digits printed; the range from low to high includes it.
By their numbers in this assay, from the lowest: compounds 1, 3 and 4 (each within the scatter of the next). At a limit, above all of these: compound 2.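

In this assay, 4-bromophenyl on the double-bonded chain carbon brings a six-membered aromatic ring of carbon only to this place, yet the read-out stays put: no change at the digits printed from compound 3 to compound 4 (within the scatter) and no change at the digits printed from compound 1 to compound 4 (within the scatter). Among the compounds shown, 4-bromophenyl, 3-methylthiophen-2-yl and 1H-indol-3-yl therefore read alike here, while 2,4,6-trihydroxyphenyl alone goes against this, with an at least 4.0-fold lower number from compound 2 to compound 4 (0.60 log units; beyond the scatter). Compound 2 stands at a limit of the assay and not a number: the limit of > 100000 nM in this assay, at which 1 of the 4 values shown sits.

Still open, going by these compounds, is whether an amine or a carboxylic acid in place of the bromine would shift the number, and in which direction.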